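Three Amides, One Unmeasured Pyridine Amide

The source may hold more compounds than are shown below. What is called first, only, known or untested is meant among the compounds shown, and "the series" means these compounds.

Measured in a physicochemical assay for solubility, read by LC-MS, in phosphate buffer, with a stated time of 24 h, at pH 7.4; on this read-out lower numbers stand for lower solubility and higher numbers for higher solubility:
- Compound 1 `COCCC(=O)Nc1cnc(NCc2c(F)ccc3c2CCO3)n2cnnc12`: 980000 nM
- Compound 2 `CC1(C)CC(=O)N(c2cnc(NCc3c(F)ccc4c3CCO4)n3cnnc23)C1`: 57000 nM
- Compound 3 `CN(C(=O)c1ccccc1)c1cnc(NCc2c(F)ccc3c2CCO3)n2cnnc12`: 280000 nM

Compound 3 stands second highest of the three. Compound 4 `O=C(Nc1cnc(NCc2c(F)ccc3c2CCO3)n2cnnc12)c1cccnc1` carries ((pyridin-3-yl)carbonyl)amino in place of benzoyl(methyl)amino on an aromatic carbon. It keeps an aromatic ring, as compound 3 does, and has an amide hydrogen, as compound 1 does. The closest evidence is a 3.5-fold lower number from compound 1 to compound 3 (0.54 log units; beyond the scatter), a modest step. a 4.9-fold higher number from compound 2 to compound 3 (0.69 log units; beyond the scatter) and a 17-fold lower number from compound 1 to compound 2 (1.24 log units; beyond the scatter) involve a group unlike the incoming one, so they bear less on it. No step beyond the scatter is therefore expected in this assay. The estimate means a 1.4-fold lower number from compound 3 to compound 4 (0.15 log units; within the scatter), an expected change within the scatter. Compound 4 is estimated at 200000 nM, with an expected range of 50000 nM to 600000 nM.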

Compound 4, solubility: 12000 nM
For compound 4 the middle estimate is 17-fold (1.22 log units) above the measured one; measured number outside the range, below it.
By their numbers in this assay, from the lowest: compound 4; then compound 2; then compound 3; then compound 1.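

In this assay, ((pyridin-3-yl)carbonyl)amino gives a 23-fold lower number from compound 3 to compound 4 (1.37 log units; beyond the scatter) and places compound 4 lowest of the four. At this position, an aromatic ring and an amide hydrogen together do not preserve the higher numbers: pyridin-3-yl on the carbonyl carbon gives an 82-fold lower number from compound 1 to compound 4 (1.91 log units; beyond the scatter) in the largest step of the set. Even the previous lowest compound lies higher, with a 4.8-fold lower number from compound 2 to compound 4 (0.68 log units; beyond the scatter) as the step. Benzoylamino, or a methyl on the amide nitrogen of compound 4, could separate the ring nitrogen from the amide hydrogen. No measurement here explains the drop.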